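A few compounds are considered here, and "the series" means these few. Any claim that something is new, unique, unknown or untested is made for them only; others in the source may bear on it.

Of the compounds shown here, two anchor the series so far in a functional assay on HCT-116 cells (Homo sapiens) for cytotoxicity, read by MTT assay, with a stated time of 72 h; on this read-out higher numbers stand for weaker inhibition and lower numbers for stronger inhibition. For compound 1 `O=C(NCc1ccc(F)cc1)c1nc(NCCO)c2cccnc2c1O`, the entry reads "not determined" (no result reported), so it offers no number for comparison. Compound 2 `Nc1cccc(Nc2c(C(=O)NCc3ccc(F)cc3)nc(Br)c3cccnc23)c1` gives > 10000 nM, which is a limit and not a measured value. Compound 2 therefore has no exact position, and the only reference point is the limit of > 10000 nM in this assay, at which 1 of the 2 values shown sits.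

Compound 3 `NCCCNc1c(C(=O)NCc2ccc(F)cc2)nc(Br)c2cccnc12` follows from compound 2 through one change: 3-aminopropyl in place of 3-aminophenyl on a nitrogen on an aromatic ring. Among the measured compounds shown here, no measured step shows what such a change does in this assay. A modest shift towards stronger inhibition is expected, though the result may again be only a limit. The expected step of an at least 1.2-fold lower number from compound 2 to compound 3 (0.09 log units; that floor lies within the scatter) is a rough estimate. For compound 3 the estimated value is 8000 nM, with an expected range of 2000 nM to 30000 nM.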

Compound 3, half-maximal inhibitory concentration: 18000 nM
Compound 3: middle estimate off by 2.3-fold (0.35 log units), on the low side, within the range that was stated.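

In this assay the pair compound 2 and compound 3 yields no readable step. Compound 2 gives > 10000 nM, which is a limit. The compounds shown leave open how far 3-aminopropyl and 3-aminophenyl on a nitrogen on an aromatic ring differ.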